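Shrinking the Aromatic-Ring Substituent: A Stability Forecast

The compounds below may be only part of what the source reports. "The series", "measured", "known", "first", "only" and "open" are said of these compounds alone.

In an ADME assay on microsomes from liver (Mus musculus) for metabolic stability, read by LC-MS, with a stated time of 10 min (on this read-out higher numbers stand for a more stable compound and lower numbers for a less stable compound), the three measured compounds gave these values:
compound 1, `CN(C[C@H]1Cc2c(cccc2N2CCN3CCC[C@H]3C2)CN1)[C@H]1CCCc2cccnc21`: 40.1%
compound 2, `CN1CCN(c2cccc3c2C[C@H](CN(C)[C@H]2CCCc4cccnc42)NC3)CC1`: 17%
compound 3, `CN(C[C@H]1Cc2c(cccc2N2CCN(c3ncccn3)CC2)CN1)[C@H]1CCCc2cccnc21`: 35.1%

Compound 1 stands highest of the three; compound 3 lies within the scatter of it, while compound 2 sits clearly lower. Compound 4, `CN(C[C@H]1Cc2c(cccc2N2CCNCC2)CN1)[C@H]1CCCc2cccnc21`, carries a smaller group at the same place: a group of 6 heavy atoms (4 carbon, 2 nitrogen; one six-membered non-aromatic ring with 2 hetero atoms) in place of a group of 9 heavy atoms (7 carbon, 2 nitrogen; one five-membered non-aromatic ring with 1 hetero atom, one six-membered non-aromatic ring with 2 hetero atoms), on an aromatic carbon. The step that bears on this is a number 23.1 percentage points lower from compound 1 to compound 2 (beyond the scatter), where the same nine-atom group gave way to another six-membered ring with two nitrogens, with a modest loss. The step of a number 18.1 percentage points higher from compound 2 to compound 3 (beyond the scatter) shows that what sits on the ring nitrogen also matters. A modest decrease for compound 4 is therefore expected, a number 13.1 percentage points lower from compound 1 to compound 4 (beyond the scatter), with a few less stable outcomes possible. Compound 4 is estimated at 27%, between 12% and 44%.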

Compound 4, percent of the compound remaining: 19.9%
Estimate against measurement, compound 4: 7.1 percentage points above; the range from low to high includes it.
By their numbers in this assay, from the lowest: compounds 2 and 4 (each within the scatter of the next); then compounds 3 and 1 (each within the scatter of the next).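

In this assay hydrogen and methyl on the ring nitrogen cannot be told apart, with a number 2.9 percentage points higher from compound 2 to compound 4 (within the scatter) as the step. Hydrogen in place of pyrimidin-2-yl gives a number 15.2 percentage points lower from compound 3 to compound 4 (beyond the scatter) and piperazin-1-yl in place of the nine-atom group gives a number 20.2 percentage points lower from compound 1 to compound 4 (beyond the scatter) as the result, so both larger groups stand higher than the plain piperazin-1-yl. No measurement here explains these differences. Still open, as far as these compounds go, is whether an acetyl or a benzyl group on that ring nitrogen would stand with the higher pair or the lower pair.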